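Swapping the Piperidine Amide for a Basic Piperazine Chain

The compounds below may be only part of what the source reports. "The series", "measured", "known", "first", "only" and "open" are said of these compounds alone.

Compound 1 `CN(C)CCN1CCN(c2nc(-c3ccccn3)nc3c2CN(Cc2ccccc2)CC3)CC1`: 41.3%
Compound 2 `NC(=O)C1CCN(c2nc(-c3cccnc3)nc3c2CN(Cc2ccccc2)CC3)CC1`: "not active" (no number reported)

In an assay on FRT cells with Cystic fibrosis transmembrane conductance regulator variant F508del (Homo sapiens) as the target, read by fluorescence, with a stated time of 25 min (on this read-out lower numbers stand for smaller maximal responses and higher numbers for larger maximal responses), compound 2 gives "not active" (no number reported), so no number places it on the scale. Compound 3 `CN(C)CCN1CCN(c2nc(-c3cccnc3)nc3c2CN(Cc2ccccc2)CC3)CC1` keeps the core of compound 2 and changes one group: 4-(2-(dimethylamino)ethyl)piperazin-1-yl in place of 4-carbamoylpiperidin-1-yl on an aromatic carbon. Going by the values given here, compound 1 carries the same entering group, though it differs elsewhere, and in this assay compound 1 gives 41.3%; no step between those two has been measured. For compound 3 a rise beyond the scatter toward a measurable response is expected. Compound 3 is estimated at 30%, within 0% to 55%.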

Compound 3, largest response reached (Emax), in percent of the reference or control that the assay uses: "not active" (no number reported)
For compound 3 the study gives words and no number; no gap can be computed for the estimate.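

In this assay compound 2 and compound 3 both read "not active", so no step can be read between them. As far as these compounds go, what this group swap does to the response stays open. No supporting measurement explains the result.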